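Changing the amide aryl group from compound 3 to compound 4

The compounds below may be only part of what the source reports. "The series", "measured", "known", "first", "only" and "open" are said of these compounds alone.

Measured compounds:
compound 1, `CCCCCCCCn1cc(COC2(C(F)(F)F)Oc3ccccc3C=C2C(=O)OCC)nn1`, > 150000 nM
compound 2, `CCOC(=O)C1=Cc2ccccc2OC1(OCc1cn(-c2cccc(C(F)(F)F)c2)nn1)C(F)(F)F`, > 150000 nM
compound 3, `CCOC(=O)C1=Cc2ccccc2OC1(OCc1cn(CC(=O)Nc2cccc(Cl)c2)nn1)C(F)(F)F`, 10100 nM

In a functional assay on DU-145 cells (Homo sapiens) for inhibition, read by MTT assay, with a stated time of 24 h (on this read-out higher numbers stand for weaker inhibition and lower numbers for stronger inhibition), compound 1 reaches only the limit > 150000 nM. Compound 2 likewise reaches only the limit > 150000 nM. For the measured compounds named here, compound 3 is the one compound with a number, 10100 nM, and the steps of an at least 14-fold lower number from compound 1 to compound 3 (1.17 log units; beyond the scatter) and an at least 14-fold lower number from compound 2 to compound 3 (1.17 log units; beyond the scatter) both point the same way, since the limit of > 150000 nM in this assay, at which 2 of the 3 values shown sit, applies to compounds 1 and 2.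

Compound 4, `CCOC(=O)C1=Cc2ccccc2OC1(OCc1cn(CC(=O)Nc2ccc(I)cc2Cl)nn1)C(F)(F)F`, is not yet measured. Its difference from compound 3 is 2-chloro-4-iodophenyl in place of 3-chlorophenyl on an amide-type nitrogen: the 3-chlorophenyl ring leaves and a 2-chloro-4-iodophenyl ring enters, with the carbamoyl group kept. Going by the values given here, no measured step touches this ring, so the large steps to compound 3 give no direction here. Compound 4 is therefore expected to stay close to compound 3, with a 1.0-fold lower number from compound 3 to compound 4 (0.00 log units; within the scatter), an estimated 10000 nM between 3000 nM and 35000 nM.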

Compound 4, half-maximal inhibitory concentration: 24400 nM
For compound 4 the middle estimate is 2.4-fold (0.39 log units) below the measured one; the measured number falls inside the stated range.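

In this assay, for the compounds shown here, the aryl ring on the amide-type nitrogen responds to change, with a 2.4-fold higher number from compound 3 to compound 4 (0.38 log units; beyond the scatter), the first readable step at this position. Compound 4 nevertheless keeps a clear margin over the compounds without the carbamoyl group, with an at least 6.1-fold lower number from compound 2 to compound 4 (0.78 log units; beyond the scatter) and an at least 6.1-fold lower number from compound 1 to compound 4 (0.78 log units; beyond the scatter). Both of these steps start from a limit rather than a number: the limit of > 150000 nM in this assay, at which 2 of the 4 values shown sit.

The compounds shown do not separate the contribution of the 2-chloro group from that of the 4-iodo group. Going by these compounds, how an unsubstituted phenyl ring, or one carrying an amine or a carboxylic acid, would read also remains open.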